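Three bromo groups on the bis-enone core

The source may hold more compounds than are shown below. What is called first, only, known or untested is meant among the compounds shown, and "the series" means these compounds.

Measured so far:
compound 1, `Cc1cc(O)c(C(=O)/C=C/c2cccc3ccccc23)c(-c2ccccc2)c1C(=O)/C=C/c1cccc2ccccc12`: "not active" (no number reported)
compound 2, `Cc1cc(O)c(C(=O)/C=C/c2ccc(Br)cc2)c(-c2ccc(OCc3ccccc3)cc2)c1C(=O)/C=C/c1ccc(Br)cc1`: 30000 nM
compound 3, `Cc1cc(O)c(C(=O)/C=C/c2ccc(OCc3ccccc3)cc2)c(-c2ccc(Br)cc2)c1C(=O)/C=C/c1ccc(OCc2ccccc2)cc1`: 20000 nM

All three share one core carrying a hydroxy, a methyl and two enone arms. In a functional assay on MDA-MB-231 cells (Homo sapiens) for cytotoxicity, read by MTT assay, with a stated time of 24 h (a higher number here means a weaker inhibitor, a lower number a stronger inhibitor), compound 1 gives "not active" (no number reported), with no number reported. In this assay compound 2 gives 30000 nM and compound 3 gives 20000 nM. Within the data shown here, these two numbers sit within the usual scatter of each other, so no order between compound 2 and compound 3 can be read; both are weak inhibitors, and compound 2 is one of only two compounds with a number at all.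

Compound 4, `Cc1cc(O)c(C(=O)/C=C/c2ccc(Br)cc2)c(-c2ccc(Br)cc2)c1C(=O)/C=C/c1ccc(Br)cc1`, follows from compound 2 by bromo in place of benzyloxy on an aromatic carbon. Among the measured compounds shown here, no step between measured compounds that differ in one place has been determined, so the size of this change is not known from the series itself. Compound 2 and compound 3 differ in more than one place, exchanging bromo and benzyloxy on the arms and the pendant ring, yet their numbers sit within the scatter, which gives no sign that this exchange shifts the number much. In this assay the expected step is therefore a 1.2-fold higher number from compound 2 to compound 4 (0.07 log units; within the scatter), none beyond the scatter. The number estimated for compound 4 is 35000 nM, with a range from 12000 nM to 100000 nM. Since compound 1 returned no number, a result without a number remains possible for compound 4 as well.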

Compound 4, half-maximal inhibitory concentration: 18000 nM
Beside the measured number, compound 4's estimate is 1.9-fold (0.29 log units) above it, and the stated range covers the measured number.
By their numbers in this assay, from the lowest: compounds 4, 3 and 2 (each within the scatter of the next).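

In this assay, among these compounds, the exchange of benzyloxy for bromo on an aromatic carbon of a six-membered aromatic ring of carbon only, para to a large group, gives a 1.7-fold lower number from compound 2 to compound 4 (0.22 log units; within the scatter) and is the first single-place step. Eight heavy atoms, including an aromatic ring and a hydrogen-bond acceptor, leave and a single bromine enters, yet the number does not move beyond the scatter, so between these two compounds the benzyloxy group shows no measurable contribution at this position. No evidence is at hand that could explain this result.

On these data alone, whether a different kind of group at this aromatic carbon, such as an amine, a carboxylic acid or a longer alkoxy chain, would give a step beyond the scatter in this assay remains open. Also open, as far as these compounds go, is what a single change on the enone arms does to the number, and whether any such change could move it away from the weak range seen so far.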